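One Six-Membered Ring Exchanged for Another on the Core

A few compounds are considered here, and "the series" means these few. Any claim that something is new, unique, unknown or untested is made for them only; others in the source may bear on it.

Of the compounds shown here, three built on one shared core have been tested in a functional assay for inhibition of sodium/hydrogen exchanger (Oryctolagus cuniculus); a lower number here means a stronger inhibitor, a higher number a weaker inhibitor. Compound 1 `Cc1cc(-c2ccc(F)cc2)c(S(C)(=O)=O)cc1C(=O)N=C(N)N` gives 36 nM, compound 2 `Cc1cc(SC(C)C)c(S(C)(=O)=O)cc1C(=O)N=C(N)N` gives 12 nM, and compound 3 `Cc1cc(Nc2ncccn2)c(S(C)(=O)=O)cc1C(=O)N=C(N)N` gives 8.3 nM. Compound 3 has the lowest number of the three, but compound 2 lies within the scatter of it, so no order between those two can be claimed; only compound 1 stands clearly apart. The steps show this: a 3.0-fold lower number from compound 1 to compound 2 (0.48 log units; beyond the scatter) and a 4.3-fold lower number from compound 1 to compound 3 (0.64 log units; beyond the scatter), while a 1.4-fold lower number from compound 2 to compound 3 (0.16 log units; within the scatter).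

Compound 4 `Cc1cc(-n2ccc(=O)cc2)c(S(C)(=O)=O)cc1C(=O)N=C(N)N` has not yet been measured. It differs from compound 3 in one place: a group of 7 heavy atoms (5 carbon, 1 nitrogen, 1 oxygen; one six-membered aromatic ring with 1 hetero atom) in place of a group of 7 heavy atoms (4 carbon, 3 nitrogen; one six-membered aromatic ring with 2 hetero atoms), on an aromatic carbon. Within the data shown here, of the measured steps, only the one from compound 2 to compound 3 replaces the isopropylsulfanyl group by another group at this same position, and that step stayed within the scatter; no measured step involves the entering group itself. A step of similarly small size is therefore expected, in either direction. Compound 4 is estimated to give about 12 nM, with a range from 4 nM to 40 nM. The expected step is a 1.4-fold higher number from compound 3 to compound 4 (0.16 log units; within the scatter).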

Compound 4, half-maximal inhibitory concentration: 75 nM
The estimate for compound 4 lay 6.3-fold (0.80 log units) below the measured number; measured number above the stated range.
By their numbers in this assay, from the lowest: compounds 3 and 2 (each within the scatter of the next); then compound 1; then compound 4.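

This position turns out not to be indifferent to what sits on it: in this assay the change gives a 9.0-fold higher number from compound 3 to compound 4 (0.96 log units; beyond the scatter) and, against the isopropylsulfanyl group, a 6.3-fold higher number from compound 2 to compound 4 (0.80 log units; beyond the scatter) as well. Even the 4-fluorophenyl group keeps the number lower, with a 2.1-fold higher number from compound 1 to compound 4 (0.32 log units; beyond the scatter) showing that compound 4 is the weakest inhibitor of the four. Matching size is thus no guide here, since the entering and leaving groups both hold 7 heavy atoms and one six-membered aromatic ring, though the leaving group has 1 hydrogen-bond donor and the entering group 0.

Going by these compounds, whether a simple amine or a methoxy group on this carbon would keep the number low remains open. The compounds shown offer no measurement that explains the rise in compound 4.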